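A Methoxy Added Beside the Chloro Group

The source may hold more compounds than are shown below. What is called first, only, known or untested is meant among the compounds shown, and "the series" means these compounds.

Of the compounds shown here, two sharing one core have been measured in an assay on isolated protein for displacement of a labelled ligand from metabotropic glutamate receptor 5 (Homo sapiens), with a stated time of 60 min, tested at 1 uM; on this read-out higher numbers stand for more inhibition at the one concentration tested (going by the name of the read-out) and lower numbers for less inhibition. Compound 1 `CC1CCN(c2c(S(=O)(=O)c3cccc(Cl)c3)cnc3cc(Cl)ccc23)CC1` gives 92% in this assay. Compound 2 `Cc1ccc(S(=O)(=O)c2cnc3cc(F)ccc3c2N2CCC(C)CC2)cc1Cl` gives 93% in this assay. Compound 1 stands at the lower of the two numbers, yet the number of compound 2 lies only slightly higher, so the two values are within the scatter of each other and no order between them can be claimed.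

Compound 3 `COc1ccc(S(=O)(=O)c2cnc3cc(Cl)ccc3c2N2CCC(C)CC2)cc1Cl` has not yet been measured. Compared with compound 1 the change is methoxy in place of hydrogen on an aromatic carbon. Nothing measured here follows a change of this kind, so the expectation rests on the two measured values alone, both of which sit high in this assay.

On that basis the step of a number 3 percentage points lower from compound 1 to compound 3 (within the scatter) is expected to be small, with no direction beyond the scatter. Compound 3 is therefore estimated to give about 89% in this assay, within a range from 76% to 97%.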

Compound 3, a percentage reported as inhibition, at one concentration (the size of the read-out at that concentration, not a potency): 93%
Beside the measured number, compound 3's estimate is 4 percentage points below it; the measured number falls inside the stated range.
By their numbers in this assay, from the lowest: compounds 1, 2 and 3 (each within the scatter of the next).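

Going from 3-chlorophenyl to 3-chloro-4-methoxyphenyl, this assay shows a number 1 percentage points higher from compound 1 to compound 3 (within the scatter), so this aromatic carbon, ortho to a chloro group and para to a large group, carries a methoxy without the number leaving the scatter of compound 1. Going by these compounds alone, this is the first change that can be read in one place, and it shows that the added oxygen and carbon cost nothing that this read-out can detect, although a reading at one concentration with compound 1 already at 92% leaves little room to tell the two compounds apart. Nothing available here explains why the number holds at this position.

The compounds shown leave open whether the number would stay level with something other than methoxy on this carbon, such as a carboxylic acid, a dimethylamino group or a longer chain like butoxy. They also leave open how compound 1 and compound 3 would compare as full concentration curves, and whether the methoxy would read the same with the chloro group gone from the ring.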